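The compounds below may be only part of what the source reports. "The series", "measured", "known", "first", "only" and "open" are said of these compounds alone.

Of the compounds shown here, two with the same core have been measured in a functional assay on a cell-free system (Platelet, plasma, Homo sapiens) for inhibition; a higher number here means a weaker inhibitor, a lower number a stronger inhibitor. Compound 1 `Cc1ccc(N(CCN2CCC(OCC(=O)O)CC2)C(=O)c2ccc(Cl)cc2)cc1`, which carries a 4-chlorophenyl on the carbonyl carbon, gives 690 nM. Compound 2 `Cc1ccc(N(CCN2CCC(OCC(=O)O)CC2)C(=O)c2cccc(Cl)c2)cc1`, with a 3-chlorophenyl in that place, gives 100 nM, the lower of the two numbers, which makes it the stronger inhibitor of the pair. Compound 3 `Cc1ccc(N(CCN2CCC(OCC(=O)O)CC2)C(=O)c2cccc(C)c2)cc1` differs from compound 2 in a single group, with methyl in place of chloro on an aromatic carbon, meta to a large group: methyl in place of chloro on an aromatic carbon. Among the measured compounds shown here, only one measured step bears on this change, a 6.9-fold lower number from compound 1 to compound 2 (0.84 log units; beyond the scatter). For the measured compounds named here, that step shows that moving the chloro can shift the number beyond the scatter, but it involves no replacement of the chloro, and no measured compound has a methyl in its place. The evidence for a direction is therefore thin, and only a small rise, probably not beyond the scatter, is expected in this assay. The expected step is a 1.5-fold higher number from compound 2 to compound 3 (0.18 log units; within the scatter). The estimated value for compound 3 is 150 nM, with an expected range of 50 nM to 450 nM.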

Compound 3, half-maximal inhibitory concentration: 160 nM
Beside the measured number, compound 3's estimate is 1.1-fold (0.03 log units) below it; the measured number falls inside the stated range.
By their numbers in this assay, from the lowest: compounds 2 and 3 (each within the scatter of the next); then compound 1.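

In this assay, the first direct replacement of the chloro at this place, on an aromatic carbon meta to a large group, gives a 1.6-fold higher number from compound 2 to compound 3 (0.20 log units; within the scatter). Chloro and methyl therefore cannot be told apart here, whereas the earlier compounds showed only that moving the chloro mattered. The 3-methylphenyl of compound 3 also stays clear of the 4-chlorophenyl of compound 1 (a 4.3-fold lower number from compound 1 to compound 3 (0.63 log units; beyond the scatter)), so among these three compounds, both groups at this place give lower numbers than the 4-chlorophenyl, and no compound here goes against that; nothing available explains these numbers.

From the compounds shown here alone, it remains open whether a quite different group at this place, such as a methoxy, a nitrile or an amine, would stay within the scatter of compound 2 and compound 3 or move the number clearly in either direction. Going by these compounds, it is also open whether a 4-methylphenyl on the carbonyl carbon would match the 4-chlorophenyl of compound 1, which would show whether the gap seen with the chloro also holds for methyl.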